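The compounds below may be only part of what the source reports. "The series", "measured", "known", "first", "only" and "open" are said of these compounds alone.

In a functional assay on MDA-MB-231 cells (Homo sapiens) for cytotoxicity, read by MTT assay, with a stated time of 72 h (a lower number here means a stronger inhibitor, a higher number a weaker inhibitor), compound 2 (`Cc1ccccc1NC(=O)CN1CCN(c2nnc(Cc3ccccc3)c3ccccc23)CC1`) gives 17300 nM and compound 3 (`O=C(CN1CCN(c2nnc(Cc3ccccc3)c3ccccc23)CC1)Nc1cc(C(F)(F)F)ccc1Cl`) gives 19500 nM within the scatter of each other, while compound 1 (`O=C(CN1CCN(c2nnc(Cc3ccncc3)c3ccccc23)CC1)Nc1cccc(Br)c1`) lies far lower at 1.7 nM in the same test. Compound 4 (`Cc1ccccc1NC(=O)CN1CCN(c2nnc(Cc3ccncc3)c3ccccc23)CC1`) departs from compound 2 with pyridin-4-yl in place of phenyl on a saturated chain carbon bound to an aromatic carbon. For the measured compounds named here, the only measured step, a 1.1-fold higher number from compound 2 to compound 3 (0.05 log units; within the scatter), concerns the amide-type nitrogen and not this place. Going by the values given here, compound 1 carries pyridin-4-yl at 1.7 nM but also differs on the amide-type nitrogen, so no measured step isolates the change. The expected change is a large drop, an 87-fold lower number from compound 2 to compound 4 (1.94 log units; beyond the scatter), though very uncertain. For compound 4 the estimated value is 200 nM (range 3 nM to 20000 nM).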

Compound 4, half-maximal inhibitory concentration: 200 nM
Compound 4: middle estimate and measured number agree at the digits printed; measured number inside the range.
By their numbers in this assay, from the lowest: compound 1; then compound 4; then compounds 2 and 3 (each within the scatter of the next).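

In this assay, pyridin-4-yl in place of phenyl now has a step of its own: with 2-methylphenyl held on the amide-type nitrogen, the change gives an 87-fold lower number from compound 2 to compound 4 (1.94 log units; beyond the scatter) and is large by itself. The group on the amide-type nitrogen also matters while pyridin-4-yl stays in place, with a 120-fold higher number from compound 1 to compound 4 (2.07 log units; beyond the scatter) as 2-methylphenyl replaces 3-bromophenyl. Nothing available explains either step.

On these data alone, it remains open whether pyridin-3-yl at this place would give a similar number. Also open, as far as these compounds go, is whether 3-bromophenyl would bring such a large step alongside phenyl.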